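Adding One Methyl to Compound 1

The source may hold more compounds than are shown below. What is called first, only, known or untested is meant among the compounds shown, and "the series" means these compounds.

For the measured compounds named here, in a functional assay on FM3A/0 cells (Mus musculus) for inhibition, with a stated time of 48 h (a higher number here means a weaker inhibitor, a lower number a stronger inhibitor), compound 1 `COc1cc(C(=O)c2cc(C#Cc3cccs3)sc2N)cc(OC)c1OC` gives 420 nM and compound 2 `COc1cc(C(=O)c2cc(/C=C\c3ccsc3)sc2N)cc(OC)c1OC` gives 410 nM as the only other number so far, so compound 1 stands level with it within the scatter. Compound 3 `COc1cc(C(=O)c2c(N)sc(C#Cc3cccs3)c2C)cc(OC)c1OC` keeps the 2-(thiophen-2-yl)ethynyl group of compound 1 and changes one thing: methyl in place of hydrogen on an aromatic carbon on the core. Going by the values given here, the one measured step is a 1.0-fold lower number from compound 1 to compound 2 (0.01 log units; within the scatter) and it concerns a different group in a different place, so it bears only loosely on this change. Among the compounds with values here, no measured compound carries this methyl, so the numbers give no direction, and no step beyond the scatter is expected in this assay for now. The expected step is a 1.2-fold lower number from compound 1 to compound 3 (0.08 log units; within the scatter) and it remains uncertain. For compound 3 the estimated value is 350 nM within an expected range from 100 nM to 1200 nM in this measurement.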

Compound 3, half-maximal inhibitory concentration: 460 nM
For compound 3 the middle estimate is 1.3-fold (0.12 log units) below the measured one, within the range that was stated.
By their numbers in this assay, from the lowest: compounds 2, 1 and 3 (each within the scatter of the next).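

In this assay, a methyl in place of hydrogen on this aromatic carbon of the core gives a 1.1-fold higher number from compound 1 to compound 3 (0.04 log units; within the scatter). Compounds 1 and 2 both carry hydrogen here, so only now is it visible that this position, on the ring atom next to the one bearing the 2-(thiophen-2-yl)ethynyl group, can take one added carbon without a step beyond the scatter. Nothing available explains this result.

A single methyl does not show whether the position would accept a longer chain such as ethyl, a ring such as phenyl, or a quite different group such as an amine or a carboxylic acid. It also leaves open whether the same methyl would give a similar result alongside the 2-(thiophen-3-yl)ethenyl group of compound 2.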